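Exchanging the cyanophenyl arm of compound 1 for pyridyl

The source may report more compounds than this note shows. Statements on the series, on what has been measured and on what is new or still open speak of the compounds shown alone.

Compound 1 `N#Cc1cccc(C2=NC(c3ccc(F)cc3)(c3ccc(F)cc3)CN2)c1` carries a 3-cyanophenyl group on the carbon with a double bond to nitrogen of its shared core. In an assay on LM cells for displacement of a labelled ligand from Neuropeptide Y receptor type 5 (Homo sapiens) (a lower number here means a stronger inhibitor, a higher number a weaker inhibitor), compound 1 gives 2.7 nM, the lowest of the two numbers measured here. Its nearest neighbour is compound 2 `Cc1cccc(C2=NC(c3ccc(F)cc3)(c3ccc(F)cc3)CN2)c1` at 30 nM, a step of an 11-fold higher number from compound 1 to compound 2 (1.05 log units; beyond the scatter). Compound 3 `CN(C)c1cccc(C2=NC(c3ccc(F)cc3)(c3ccc(F)cc3)CN2)c1` reaches only > 1000 nM in this assay, which is a limit rather than a number. The step to it is an at least 370-fold higher number from compound 1 to compound 3 (2.56 log units; beyond the scatter).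

Compound 4 `Fc1ccc(C2(c3ccc(F)cc3)CNC(c3cccnc3)=N2)cc1` is not yet measured; it differs from compound 1 in that (pyridin-3-yl in place of 3-cyanophenyl on a carbon with a double bond to nitrogen). The measured steps bear on this only in part: both kept the phenyl ring and replaced the cyano group, and both cost potency. Here the whole ring changes, yet the pyridin-3-yl, like the 3-cyanophenyl, offers a hydrogen-bond acceptor. A moderate loss is therefore expected, as a 5.6-fold higher number from compound 1 to compound 4 (0.74 log units; beyond the scatter). Compound 4 is estimated at 15 nM, within 4 nM to 60 nM.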

Compound 4, half-maximal inhibitory concentration: 7.2 nM
Beside the measured number, compound 4's estimate is 2.1-fold (0.32 log units) above it, within the range that was stated.
By their numbers in this assay, from the lowest: compound 1; then compound 4; then compound 2. At a limit, above all of these: compound 3.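

Replacing the whole 3-cyanophenyl arm costs little, with a 2.7-fold higher number from compound 1 to compound 4 (0.43 log units; beyond the scatter), so a low number at this carbon depends on neither the nitrile nor an all-carbon aromatic ring, although compound 1 keeps the lower number. The pyridin-3-yl arm also improves on the 3-methylphenyl arm, with a 4.2-fold lower number from compound 2 to compound 4 (0.62 log units; beyond the scatter), so among these arms a smaller ring that carries a hydrogen-bond acceptor does better than a methyl-bearing phenyl ring. The last step, an at least 130-fold lower number from compound 3 to compound 4 (2.14 log units; beyond the scatter), rests on a limit rather than a number: the limit of > 1000 nM in this assay, at which 1 of the 4 values shown sits.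

Going by these compounds, it remains open how the pyridin-2-yl and pyridin-4-yl arms, with the ring nitrogen elsewhere, would compare. Also open, on these data alone, is whether adding a nitrile to the pyridine ring would give a lower number than either compound 1 or compound 4.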